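Swapping a piperidine substituent and the expected half-life

The compounds below may be only part of what the source reports. "The series", "measured", "known", "first", "only" and "open" are said of these compounds alone.

Measured compounds:
- compound 1, `CCCCCOC(=O)N1CCN(C(=O)[C@H](CCC(=O)O)NC(=O)c2cc(N3CCC(OCCO)CC3)nc(-c3ccccc3)n2)CC1`, 0.00833 h
- compound 2, `CCCCCOC(=O)N1CCN(C(=O)[C@H](CCC(=O)O)NC(=O)c2nc(-c3ccccc3)cc(N3CCC(CN)CC3)n2)CC1`, 0.00333 h

In an in vivo ADME assay on the whole organism (strain Sprague-Dawley) for metabolic stability, with Rattus norvegicus as the target (on this read-out lower numbers stand for a shorter-lived compound and higher numbers for a longer-lived compound), compound 1 gives 0.00833 h, the higher of the two values, and the gap down to compound 2 at 0.00333 h lies beyond the usual scatter of this assay. Among the measured compounds shown here, compound 2 differs from compound 1 in more than one place, so no single step links them; the two values are simply what each compound shows.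

Compound 3, `CCCCCOC(=O)N1CCN(C(=O)[C@H](CCC(=O)O)NC(=O)c2cc(N3CCC(C(N)=O)CC3)nc(-c3ccccc3)n2)CC1`, is not yet measured. It differs from compound 1 in one place: carbamoyl in place of 2-hydroxyethoxy on a saturated ring carbon of the piperidine attached to the shared core. The rest of the molecule is unchanged.

For the measured compounds named here, no measured pair shows what this change does. The step from compound 1 to compound 3 in this assay is therefore expected to stay within the scatter, with no clear direction, as a 1.0-fold lower number from compound 1 to compound 3 (0.02 log units; within the scatter). Compound 3 is expected to give about 0.008 h, within a range from 0.003 h to 0.02 h.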

Compound 3, half-life: 0.00667 h
The estimate for compound 3 lay 1.2-fold (0.08 log units) above the measured number, within the range that was stated.
By their numbers in this assay, from the lowest: compounds 2, 3 and 1 (each within the scatter of the next, the first and the last beyond it).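

In this assay, carbamoyl in place of 2-hydroxyethoxy on a saturated ring carbon of the piperidine gives a 1.2-fold lower number from compound 1 to compound 3 (0.10 log units; within the scatter). Among the compounds shown here, this is the first pair that differs in one place, and it offers a direct reading at this position: the step from 4-(2-hydroxyethoxy)piperidin-1-yl to 4-carbamoylpiperidin-1-yl cannot be told apart from repeat-measurement noise. Nothing measured here offers an explanation for how these two groups compare.

From the compounds shown here alone, it remains open whether a simple hydroxyl, a methoxy group or a longer ether chain on the same ring carbon would give a number beyond the scatter. This step is also seen only once, and the same swap on a different shared core could read differently.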